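The compounds below may be only part of what the source reports. "The series", "measured", "known", "first", "only" and "open" are said of these compounds alone.

In a functional assay on A549 cells (Homo sapiens) for antiproliferative activity, read by MTT assay, with a stated time of 72 h (on this read-out higher numbers stand for weaker inhibition and lower numbers for stronger inhibition), three compounds built on the shared core have been measured. Compound 1 `COc1cc(-c2ccc3ncn(-c4cc(OC)c(OC)c(OC)c4)c3c2)cc(OC)c1OC` gives only a limit in this assay, > 10000 nM. Compound 2 `COc1cccc(-c2ccc3ncn(-c4cc(OC)c(OC)c(OC)c4)c3c2)c1` gives 3180 nM, and compound 3 `COc1cc(-n2cnc3ccc(-c4cccc(C)c4C)cc32)cc(OC)c1OC` gives 9250 nM. Of the two numbers available, compound 3 stands highest; its nearest neighbour is compound 2, separated from it by a 2.9-fold higher number from compound 2 to compound 3 (0.46 log units; beyond the scatter), the change being 2,3-dimethylphenyl in place of 3-methoxyphenyl on an aromatic carbon. The third value is a limit and offers no number to rank against.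

Compound 4 `COc1cc(-n2cnc3ccc(-c4cccc(C)c4)cc32)cc(OC)c1OC` differs from compound 3 by hydrogen in place of methyl on an aromatic carbon, and cut one bond further out the same difference reads 2,3-dimethylphenyl to 3-methylphenyl. Among the measured compounds shown here, no measured step removes a single methyl, so the only step that bears on this one is the modest, beyond-scatter step from compound 2 to compound 3. The 3-methylphenyl of compound 4 lies structurally between the 3-methoxyphenyl of compound 2 and the 2,3-dimethylphenyl of compound 3, so its number is expected to fall between those two, which amounts to an expected 1.9-fold lower number from compound 3 to compound 4 (0.27 log units; within the scatter). Compound 4 is estimated at 5000 nM, with a range from 1500 nM to 15000 nM.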

Compound 4, half-maximal inhibitory concentration: 3820 nM
For compound 4 the middle estimate is 1.3-fold (0.12 log units) above the measured one; low and high end bracket the measured number.
By their numbers in this assay, from the lowest: compounds 2 and 4 (each within the scatter of the next); then compound 3. At a limit, above all of these: compound 1.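

In this assay, among the compounds shown here, taking away one methyl, at the place ortho to a large group and ortho to a methyl group, gives a 2.4-fold lower number from compound 3 to compound 4 (0.38 log units; beyond the scatter), a modest step beyond the scatter and the first measured change of a single methyl on this ring. Methyl in place of methoxy on the aromatic carbon gives a 1.2-fold higher number from compound 2 to compound 4 (0.08 log units; within the scatter), so compound 2 and compound 4 cannot be told apart on this read-out, and among these three compounds only the 2,3-dimethylphenyl of compound 3 separates from the others. Nothing shown here accounts for the effect of this methyl on the number.

As far as these compounds go, whether a fluorine, a hydroxyl or an amine on the carbon that carries the methyl in compound 3 would keep the number of compound 4 or move it toward that of compound 3 stays open, as does the effect of a lone methyl at that place without the 3-methyl. From the compounds shown here alone, how these steps carry over to any other cell line also remains open.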